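Amine-side variation in a sulfonamide series: compound 4

The source may hold more compounds than are shown below. What is called first, only, known or untested is meant among the compounds shown, and "the series" means these compounds.

Measured compounds:
- compound 1 `COc1cccc(CNCCCNS(=O)(=O)c2cc(C(F)(F)F)cc(C(F)(F)F)c2)c1`: 3400 nM
- compound 2 `O=S(=O)(NCCCNCC1COc2ccccc2O1)c1cc(C(F)(F)F)cc(C(F)(F)F)c1`: 2600 nM
- compound 3 `O=S(=O)(NCCCNCc1ccc(Cl)c(C(F)(F)F)c1)c1cc(C(F)(F)F)cc(C(F)(F)F)c1`: 7400 nM

In a functional assay on MIA PaCa-2 cells (Homo sapiens) for inhibition, read by MTT assay, with a stated time of 72 h (on this read-out lower numbers stand for stronger inhibition of growth and higher numbers for weaker inhibition of growth), compound 1 gives the second highest of the three numbers; its nearest neighbour is compound 2 a 1.3-fold lower number from compound 1 to compound 2 (0.12 log units; within the scatter) and its furthest compound 3 a 2.2-fold higher number from compound 1 to compound 3 (0.34 log units; beyond the scatter). Compound 4 `CN(CCCNS(=O)(=O)c1cc(C(F)(F)F)cc(C(F)(F)F)c1)Cc1ccccc1` differs from compound 1 by benzyl(methyl)amino in place of (3-methoxybenzyl)amino on a saturated chain carbon, three bonds along the chain from a sulfonamide nitrogen. Among the compounds with values here, the measured steps all swap the aryl group on the benzylic carbon, and each was modest, a 2.8-fold higher number from compound 2 to compound 3 (0.45 log units; beyond the scatter) included; none touches the amine itself, so no step bears directly on this change. Compound 4 is therefore expected to show little movement beyond the scatter, a 1.0-fold higher number from compound 1 to compound 4 (0.01 log units; within the scatter), with the estimate for compound 4 put at 3500 nM within 1500 nM to 8000 nM.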

Compound 4, concentration for 50% growth inhibition: 33000 nM
The estimate for compound 4 lay 9.4-fold (0.97 log units) below the measured number; measured number outside the range, above it.
By their numbers in this assay, from the lowest: compounds 2 and 1 (each within the scatter of the next); then compound 3; then compound 4.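

In this assay, benzyl(methyl)amino in place of (3-methoxybenzyl)amino gives a 9.7-fold higher number from compound 1 to compound 4 (0.99 log units; beyond the scatter), a larger step than any of the earlier swaps of the aryl group. This place therefore responds more strongly than those swaps indicated, and the entering group has no hydrogen-bond donor where the leaving group has one. No measured evidence bears on the origin of this step. Open, from the compounds shown here alone, is whether the methyl on the amine nitrogen or the loss of the methoxy group accounts for it. Benzylamino and (3-methoxybenzyl)(methyl)amino analogues would separate the two.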